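A few compounds are considered here, and "the series" means these few. Any claim that something is new, unique, unknown or untested is made for them only; others in the source may bear on it.

Going by the values given here, in an ADME assay on HepG2 cells (Homo sapiens) for cytotoxicity, read by luminescence, CellTiter-Glo and ATP content, with a stated time of 72 h (on this read-out lower numbers stand for an effect already at smaller amounts and higher numbers for an effect only at larger amounts of compound), compound 1 `COc1ccccc1Oc1ccc2c(NCCCNCc3ccco3)ccnc2c1` gives 6500 nM, the highest of the three numbers measured so far. Compound 3 `COc1ccc(F)cc1CNCCCNc1ccnc2cc(CCc3ccccc3)ccc12` gives 4240 nM, the nearest to compound 1 and within the scatter of it. Compound 2 `COc1ccc(F)cc1CNCCCNc1ccnc2cc(C3CCCCC3)ccc12` gives 2290 nM, the furthest from compound 1 and beyond the scatter. Among the compounds with values here, the only step measured between two compounds that differ in one place is a 1.9-fold higher number from compound 2 to compound 3 (0.27 log units; within the scatter); it concerns a substituent on an aromatic carbon of the shared core and stays within the scatter.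

Compound 4 `COc1cccc(Oc2ccc3c(NCCCNCc4ccco4)ccnc3c2)c1` is the next to be measured. It has the same atoms as compound 1, joined differently: 3-methoxyphenyl in place of 2-methoxyphenyl on an oxygen on an aromatic ring. Within the data shown here, no measured step touches the oxygen on the aromatic ring at which this change sits; the one step that exists lies elsewhere on the core and, being within the scatter, offers no pointer in either direction. With nothing in the measured steps to anchor a shift, the expectation for compound 4 in this assay is no step beyond the scatter, no change at the digits printed from compound 1 to compound 4 (within the scatter). Compound 4 is therefore estimated at 6500 nM, with a range from 3000 nM to 14000 nM.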

Compound 4, half-maximal effective concentration: 15500 nM
Beside the measured number, compound 4's estimate is 2.4-fold (0.38 log units) below it, outside the stated range (above it).
By their numbers in this assay, from the lowest: compounds 2, 3 and 1 (each within the scatter of the next, the first and the last beyond it); then compound 4.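

Going by these compounds alone, the oxygen on an aromatic ring is a place that responds in this assay: 3-methoxyphenyl in place of 2-methoxyphenyl gives a 2.4-fold higher number from compound 1 to compound 4 (0.38 log units; beyond the scatter) and is the first step to lie beyond the scatter, though a modest one. The two groups have the same heavy atoms, the same aromatic ring and the same counts of donors and acceptors, so this step involves only how those atoms are joined, whereas the earlier step between two measured compounds stayed within the scatter and concerned a different substituent on the core. The data shown offer no measurement that accounts for this step, which therefore stands as an observation only.

The compounds shown leave open whether the step is specific to methoxy or also appears when an ethoxy group, a chlorine atom or a dimethylamino group takes its place on the same aromatic ring. On these data alone, it also remains open whether the same change gives a step of similar size on compounds carrying the side chain of compound 2 and compound 3 rather than that of compound 1.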